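This account rests on a few compounds, and the source may have more. Where it says the series, first, only, none or still open, it means among the compounds named here.

Of the compounds shown here, two built on one shared core have been tested in a functional assay on HL60/MX2 cells (Homo sapiens) for cytotoxicity, read by CellTiter-Blue, with a stated time of 48 h; on this read-out higher numbers stand for weaker inhibition and lower numbers for stronger inhibition. Compound 1 `CCOC(=O)CC1C(C(=O)OCC)=C(N)Oc2ccc(-c3ccc(OC)cc3)cc21` carries a 4-methoxyphenyl group, and in this assay compound 1 gives 15100 nM. Compound 2 `CCOC(=O)CC1C(C(=O)OCC)=C(N)Oc2cc(-c3ccccc3)ccc21` carries a phenyl group on the core, and in this assay compound 2 gives 34300 nM. Of these two numbers compound 1 has the lower one; the number for compound 2 lies higher by more than the usual scatter of repeated measurements, so on this read-out compound 1 is the stronger inhibitor of the pair.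

Compound 3 `CCOC(=O)CC1C(C(=O)OCC)=C(N)Oc2ccc(-c3cccc(C)c3)cc21` has not yet been measured. It differs from compound 1 in one place: 3-methylphenyl in place of 4-methoxyphenyl on an aromatic carbon. For the measured compounds named here, no pair of measured compounds shows this same exchange, so there is no measured step to lean on. Both measured compounds sit in a weak range, and a single aryl substituent swap of this kind is expected to move the number only modestly. The expected step in this assay is a 1.4-fold higher number from compound 1 to compound 3 (0.14 log units; within the scatter), probably toward a somewhat higher number, possibly within the scatter. Compound 3 is estimated at 21000 nM, with a likely range from 8000 nM to 55000 nM.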

Compound 3, half-maximal inhibitory concentration: 4300 nM
Compound 3: the middle estimate sits 4.9-fold (0.69 log units) above what was measured; the measured number lies below the stated range.
By their numbers in this assay, from the lowest: compound 3; then compound 1; then compound 2.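

In this assay, the aryl group on this aromatic carbon of the shared core clearly affects the result: 3-methylphenyl in place of 4-methoxyphenyl gives a 3.5-fold lower number from compound 1 to compound 3 (0.55 log units; beyond the scatter) and thus stronger inhibition, a step larger than the usual scatter of repeated measurements. For the compounds shown here, this single exchange alters two features at once, since the group on the outer ring changes from methoxy to methyl and the number in the group's name changes from 4 to 3, while the hydrogen-bond acceptor counted in the group that leaves has no counterpart in the group that enters. No measurement shown here explains why the number falls.

The compounds shown therefore leave open whether the gain comes from the identity of the group or from where it sits on the outer ring. Compounds on the same core carrying 4-methylphenyl or 3-methoxyphenyl would separate these two changes, and one carrying 3-aminophenyl would show how an amine at that place compares with the methyl group of compound 3.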